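This account rests on a few compounds, and the source may have more. Where it says the series, first, only, none or still open, it means among the compounds named here.

Two long-chain phosphate esters have been measured in a functional assay on DU-145 cells (Homo sapiens) for inhibition, read by MTT assay, with stated times of 18 h and 4 h; a lower number here means a stronger inhibitor, a higher number a weaker inhibitor. Compound 1, `CCCCCCCCCCCCCCCCOP(=O)(O)OCCSC(=S)N1CCCCC1`, gives 14700 nM. Compound 2, `CCCCCCCCOP(=O)(O)OCCSC(=S)N1CCCCCC1`, gives 59100 nM. Of the two numbers, compound 2 carries the higher one, and it stands apart from compound 1 by a gap that lies beyond the usual scatter of such measurements, so compound 2 is the weaker of the pair on this evidence.

The next compound, compound 3, is `CCCOP(=O)(O)OCCSC(=S)N1CCCCCC1`. It keeps the whole of compound 2 apart from one change: hydrogen in place of pentyl on a saturated chain carbon, three bonds along the chain from an oxygen on an unsaturated carbon. The chain on the phosphate side is thus cut back sharply, from octyl to propyl.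

Among the compounds with values here, no measured pair shows this exact change, so the expectation rests on the two values alone. Because compound 1 gives 14700 nM while compound 2 gives 59100 nM, the shorter chain already comes with the weaker number, and a still shorter chain is expected to weaken further. Compound 3 is therefore expected to show a step of a 2.5-fold higher number from compound 2 to compound 3 (0.40 log units; beyond the scatter) in this assay, toward a higher number. The estimate for compound 3 is 150000 nM, within a range from 50000 nM to 450000 nM.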

Compound 3, half-maximal inhibitory concentration: 86100 nM
The estimate for compound 3 lay 1.7-fold (0.24 log units) above the measured number; measured number inside the range.
By their numbers in this assay, from the lowest: compound 1; then compounds 2 and 3 (each within the scatter of the next).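

In this assay, within the data shown here, the pair gives the first direct reading of this change, with all else held the same: hydrogen in place of pentyl, which cuts octyl back to propyl, gives a 1.5-fold higher number from compound 2 to compound 3 (0.16 log units; within the scatter). Removing these five carbon atoms therefore leaves no difference that this assay can separate from ordinary repeat-to-repeat variation, so, for this pair, the full octyl chain is not shown to be needed at this position to keep the number where it stands. Nothing measured here explains why the two compounds cannot be told apart.

This single pair says nothing about chains of other lengths, so a dodecyl chain on the core of compound 2 could still give a clearly different number, and the same holds for a chain shorter than propyl, such as methyl. It also leaves open whether a group of a different kind, such as an amine or a carboxylic acid, in place of the propyl chain of compound 3 would shift the number beyond the usual scatter.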